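Tail group exchange on the shared core: compound 2 to compound 3

The compounds below may be only part of what the source reports. "The series", "measured", "known", "first", "only" and "open" are said of these compounds alone.

Two compounds of the series carry numbers in an assay on isolated protein for inhibition of sphingosine kinase 1 (Homo sapiens); on this read-out lower numbers stand for stronger inhibition and higher numbers for weaker inhibition. Compound 1 `CCCCCCCc1cn(-c2ccc(CNC(=O)[C@H]3NCC[C@@H]3O)cc2)nn1` gives 1100 nM. Among the compounds with values here, compound 2 `O=C(NCc1ccc(-c2noc(CCC3CC3)n2)cc1)[C@H]1NCC[C@@H]1O` gives 5000 nM, the higher of the two values; the gap to compound 1 lies beyond the scatter, but the two structures differ in more than one place, so no single step connects them and the gap tells only what the two values show.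

Compound 3 `CC1(c2nc(-c3ccc(CNC(=O)[C@H]4NCC[C@@H]4O)cc3)no2)CCCCC1` keeps the core of compound 2 and alters one group: 1-methylcyclohexyl in place of 2-cyclopropylethyl on an aromatic carbon. Within the data shown here, no measured step of this kind exists, so its size is an estimate. A step from compound 2 to compound 3 toward a lower number, modest but beyond the scatter, a 2.5-fold lower number from compound 2 to compound 3 (0.40 log units; beyond the scatter), is expected, because compound 1, with a longer chain at that end, gives 1100 nM. Compound 3 is therefore estimated at 2000 nM in this assay, with a range from 500 nM to 7000 nM.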

Compound 3, half-maximal inhibitory concentration: 210 nM
Estimate against measurement, compound 3: 9.5-fold (0.98 log units) above; the whole stated range lies above it.
By their numbers in this assay, from the lowest: compound 3; then compound 1; then compound 2.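

Within the data shown here, at the aromatic carbon of the five-membered aromatic ring with 2 nitrogen and 1 oxygen, 1-methylcyclohexyl in place of 2-cyclopropylethyl gives in this assay a 24-fold lower number from compound 2 to compound 3 (1.38 log units; beyond the scatter) and this large change is the first step that can be read at a single place. The position therefore responds strongly to the tail group, even though neither group has hydrogen-bond donors, hydrogen-bond acceptors or a net charge. Nothing at hand accounts for the size of this step.

This one step changes ring size, heavy-atom count and the methyl group together, so their separate shares stay unresolved. As far as these compounds go, whether cyclohexyl without the methyl, or tert-butyl, would keep the lower number at this place remains open.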